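Octyl for 4-nitrophenyl on a sulfur

The source may hold more compounds than are shown below. What is called first, only, known or untested is meant among the compounds shown, and "the series" means these compounds.

In a physicochemical assay for pharmacokinetics, at pH 7.2 (a lower number here means that the compound disappears faster, a higher number that the compound lasts longer), compound 1 `Cc1cn([C@H]2C[C@H](SSc3ccc([N+](=O)[O-])cc3)[C@@H](CO)O2)c(=O)[nH]c1=O` reaches only a limit, < 0.0834 h, and not a number. Compound 2 `C=CCSS[C@H]1C[C@H](n2cc(C)c(=O)[nH]c2=O)O[C@@H]1CO`, which carries allyl in place of 4-nitrophenyl on a sulfur, likewise reaches only a limit, < 0.0834 h. The evidence so far is therefore (the limit of < 0.0834 h in this assay, at which 2 of the 2 values shown sit).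

Compound 3 `CCCCCCCCSS[C@H]1C[C@H](n2cc(C)c(=O)[nH]c2=O)O[C@@H]1CO` has not yet been measured. It has octyl in place of 4-nitrophenyl on a sulfur, and the difference from compound 1 can be counted as octyl in place of 4-nitrophenyl on a sulfur.

For the measured compounds named here, the only measured change at this sulfur is a step that the two limits leave unreadable from compound 1 to compound 2. It gives no size to carry over to the new group, so no step beyond the usual scatter is expected in this assay, in either direction. The expected change, a step that the limit leaves unreadable from compound 1 to compound 3, is an estimate resting on limits alone, not on a measured number. For compound 3, the estimated half-life is 0.07 h, with an expected range of 0.02 h to 0.25 h, and the result may well again be only a limit.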

Compound 3, half-life: < 0.0834 h
Compound 3 ended at the assay's limit; the forecaster's own chance of this, stated with the estimate: 70%; the middle value is on the limit's open side.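

In this assay compound 3 gives < 0.0834 h, a limit and not a number. For the compounds shown here, no step from compound 1 or compound 2 to compound 3 can be read, and the evidence remains: the limit of < 0.0834 h in this assay, at which 3 of the 3 values shown sit. The actual half-lives of compound 1, compound 2 and compound 3 stay open, as does whether 4-nitrophenyl, allyl and octyl differ at all.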